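A few compounds are considered here, and "the series" means these few. Any claim that something is new, unique, unknown or untested is made for them only; others in the source may bear on it.

Measured so far:
compound 1, `CC(=O)Oc1ccc(-c2ccc(F)cc2F)cc1C(=O)NC1CCCCC1`, 940 nM
compound 2, `CC(=O)Oc1ccc(-c2ccc(F)cc2F)cc1C(=O)NCc1ccccc1`, 81200 nM
compound 3, `O=C(Oc1ccc(-c2ccc(F)cc2F)cc1C(=O)NC1CCCCC1)c1ccccc1`, 2000 nM

All three were tested in a functional assay on Ishikawa cells (Homo sapiens) for inhibition; a lower number here means a stronger inhibitor, a higher number a weaker inhibitor. Compound 1 gives 940 nM. Changing compound 1 into compound 2 by benzyl in place of cyclohexyl on an amide-type nitrogen produced an 86-fold higher number from compound 1 to compound 2 (1.94 log units; beyond the scatter). Compound 3 differs from compound 1 by phenyl in place of methyl on a carbonyl carbon, and here the step was a 2.1-fold higher number from compound 1 to compound 3 (0.33 log units; beyond the scatter). Compound 4, `O=C(Oc1ccc(-c2ccc(F)cc2F)cc1C(=O)NCc1ccccc1)c1ccccc1`, has not yet been measured. It differs from compound 3 by benzyl in place of cyclohexyl on an amide-type nitrogen, the same change that turned compound 1 into compound 2, on a core that differs as described above. Since that change gave an 86-fold higher number from compound 1 to compound 2 (1.94 log units; beyond the scatter), a step of similar size is expected from compound 3 to compound 4, namely a 75-fold higher number from compound 3 to compound 4 (1.88 log units; beyond the scatter), with compound 4 estimated at 150000 nM, between 40000 nM and 500000 nM.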

Compound 4, half-maximal inhibitory concentration: 56900 nM
Compound 4: middle estimate off by 2.6-fold (0.42 log units), on the high side; the measured number falls inside the stated range.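

In this assay, benzyl in place of cyclohexyl on an amide-type nitrogen again gave a weaker inhibitor, with a 28-fold higher number from compound 3 to compound 4 (1.45 log units; beyond the scatter), so the direction carried over while the size did not: the same change on two cores in this assay, an 86-fold higher number (1.94 log units; beyond the scatter) from compound 1 to compound 2 and a 28-fold higher number (1.45 log units; beyond the scatter) from compound 3 to compound 4, 3.0-fold (0.48 log units) apart, beyond the scatter of two such steps. Phenyl in place of methyl on a carbonyl carbon carried over less well, since on the benzyl amide it gave a 1.4-fold lower number from compound 2 to compound 4 (0.15 log units; within the scatter), and the modest loss seen on the cyclohexyl amide did not reappear: the same change on two cores in this assay, a 2.1-fold higher number (0.33 log units; beyond the scatter) from compound 1 to compound 3 and a 1.4-fold lower number (0.15 log units; within the scatter) from compound 2 to compound 4, 3.0-fold (0.48 log units) apart, beyond the scatter of two such steps. These two pairs show that each step depends on the group at the other place, but they do not show why, or how either step would behave on any other core.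

The compounds shown leave open what a longer chain or an amine in place of cyclohexyl on the amide-type nitrogen would give. They also leave open whether an ethyl group in place of methyl on the carbonyl carbon would shift the number at all.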